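Amide aryl swap on the trifluoromethyl diol amide series

A few compounds are considered here, and "the series" means these few. Any claim that something is new, unique, unknown or untested is made for them only; others in the source may bear on it.

For the measured compounds named here, the three measured members share a trifluoromethyl diol amide carried on an alkyl chain that ends in a second amide, and differ in the group on that second amide nitrogen and in chain length. Compound 1 `O=C(CCCCCCNC(=O)C(O)(O)C(F)(F)F)Nc1nccs1` carries a 1,3-thiazol-2-yl there. In a functional assay on HCT-116 cells (Homo sapiens) for inhibition, read by colorimetric assay, with a stated time of 3 days (on this read-out higher numbers stand for weaker inhibition and lower numbers for stronger inhibition), compound 1 gives 10800 nM. Compound 2 `O=C(CCCCCCNC(=O)C(O)(O)C(F)(F)F)Nc1nc2ccc(Br)cc2s1` gives 10300 nM in this assay. Compound 3 `O=C(CCCCNC(=O)C(O)(O)C(F)(F)F)Nc1ccccc1` gives 20300 nM in this assay. Compound 1 thus sits among its two neighbours with both gaps inside the usual scatter, so no order among the three can be drawn, and all three are weak inhibitors in this assay.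

Compound 4 `O=C(CCCCCCNC(=O)C(O)(O)C(F)(F)F)Nc1ccc(F)cc1F` has not yet been measured. It differs from compound 1 by 2,4-difluorophenyl in place of 1,3-thiazol-2-yl on an amide-type nitrogen. Going by the values given here, no pair of measured compounds isolates this change, so the expectation rests on the flat picture given by compound 1, compound 2 and compound 3 together. In this assay the step of a 1.3-fold higher number from compound 1 to compound 4 (0.11 log units; within the scatter) is expected to be small, within the scatter, leaning if anything towards weaker inhibition. Compound 4 is therefore estimated at 14000 nM in this assay, with a range from 6000 nM to 35000 nM.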

Compound 4, half-maximal inhibitory concentration: 18500 nM
For compound 4 the middle estimate is 1.3-fold (0.12 log units) below the measured one; measured number inside the range.
By their numbers in this assay, from the lowest: compounds 2, 1, 4 and 3 (each within the scatter of the next).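

For the compounds shown here, this pair is the first to isolate a change on the amide-type nitrogen with the chain held fixed: in this assay the swap gives a 1.7-fold higher number from compound 1 to compound 4 (0.23 log units; within the scatter), so this position takes either 1,3-thiazol-2-yl, a five-membered aromatic ring with 2 hetero atoms, or 2,4-difluorophenyl, a six-membered aromatic ring of carbon only, with no difference that can be told from the scatter. The entering group has 8 heavy atoms against 5 and 0 hydrogen-bond acceptors against 2, yet the read-out does not separate the two compounds, so neither count can be tied to inhibition in this pair. No measurement is available that bears on the reason for this flat step.

On these data alone, whether a cyclohexyl or pyridin-3-yl group on this nitrogen, or a longer chain with 1,3-thiazol-2-yl kept in place, would move the number beyond the scatter remains open. Going by these compounds alone, the role of chain length also remains unresolved: compound 3 differs from the other compounds in more than one place, and no step to it can be read.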